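The compounds below may be only part of what the source reports. "The series", "measured", "known", "first", "only" and "open" are said of these compounds alone.

Compound 1 has the structure `O=C(Nc1ccc(-c2noc(-c3cccc(NS(=O)(=O)c4cccc(Cl)c4)c3)n2)c(Cl)c1)c1cccnc1`; in a functional assay on MDA-MB-231 cells (Homo sapiens) for antiproliferative activity, read by MTT assay, with a stated time of 72 h (on this read-out lower numbers stand for stronger inhibition and higher numbers for weaker inhibition), compound 1 gives > 10000 nM, which is a limit of the assay and not a number.
Compound 2 has the structure `O=C(Nc1ccc(-c2noc(-c3cccc(NS(=O)(=O)c4ccc(C(F)(F)F)cc4)c3)n2)c(Cl)c1)c1cccnc1`; in this assay compound 2 gives > 10000 nM, again a limit and not a number.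
Compound 3 has the structure `CC(=O)Nc1ccc(S(=O)(=O)Nc2cccc(-c3nc(-c4ccc(NC(=O)c5cccnc5)cc4Cl)no3)c2)cc1`; in this assay compound 3 gives 2500 nM.

Compound 3 is thus the only one of the three with a number; the other two sit at the limit of > 10000 nM in this assay, at which 2 of the 3 values shown sit. The step of an at least 4.0-fold lower number from compound 1 to compound 3 (0.60 log units; beyond the scatter) and the step of an at least 4.0-fold lower number from compound 2 to compound 3 (0.60 log units; beyond the scatter) both run from a limit to that number, while the step that the two limits leave unreadable from compound 1 to compound 2 cannot be read.

Compound 4, `CC(=O)Nc1ccc(S(=O)(=O)Nc2cccc(-c3nc(-c4ccc(NC(=O)c5cccnc5)cc4C(F)(F)F)no3)c2)cc1`, keeps the 4-acetamidophenyl sulfonyl group of compound 3 and differs only in this: trifluoromethyl in place of chloro on an aromatic carbon. Going by the values given here, none of the measured steps touches this position; all three concern the group on the sulfonyl sulfur, so they bear on the change from compound 3 to compound 4 only in that compound 3 is the sole anchor with a number. With nothing to point in either direction, the step of a 1.2-fold higher number from compound 3 to compound 4 (0.08 log units; within the scatter) is expected to stay within the scatter. Compound 4 is therefore estimated at 3000 nM in this assay, with a range from 1000 nM to 10000 nM.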

Compound 4, half-maximal inhibitory concentration: > 10000 nM
Compound 4 gave a limit, no number; the forecaster's own chance of this, stated with the estimate: 25%; middle value at least 3.3-fold (0.52 log units) away from the limit.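

The position that carries chloro in compound 3, ortho to a large group and meta to the ((pyridin-3-yl)carbonyl)amino group, proves to matter in this assay: trifluoromethyl in place of chloro gives an at least 4.0-fold higher number from compound 3 to compound 4 (0.60 log units; beyond the scatter), whereas every earlier step concerned only the group on the sulfonyl sulfur. The 4-acetamidophenyl sulfonyl group therefore does not secure a number by itself, as compound 4 carries that group and still reaches only a limit of the assay. Compound 4 joins compound 1 and compound 2 there, leaving compound 3 as the only compound of the four with a number: the limit of > 10000 nM in this assay, at which 3 of the 4 values shown sit.

From the compounds shown here alone, the true size of this step stays open, as does whether the loss belongs to trifluoromethyl alone, or whether fluoro, methyl, methoxy or a plain hydrogen at this position would keep a number. Going by these compounds, it also remains open how this position would behave with an amine or a carboxylic acid in place of the acetamido group on the sulfonyl side.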